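The compounds below may be only part of what the source reports. "The series", "measured", "known", "first", "only" and "open" are said of these compounds alone.

Compound 1 `Cc1c(OCCCCOc2ccc(F)c(C(=O)O)c2)ccc(C(=O)CC2CCCC2)c1O` gives 81% in an assay on HEK293 cells for positive allosteric modulation of metabotropic glutamate receptor 2 (Rattus norvegicus), read by thallium flux, with a stated time of 2.5 min; a higher number here means a larger maximal response, a lower number a smaller maximal response.
Compound 2 `CCCC(=O)c1ccc(OCCCCOc2ccc(F)c(C(=O)O)c2)c(C)c1O` gives 87.5% in this assay.
Compound 3 `Cc1c(OCCCCOc2ccc(C(=O)O)c(Cl)c2)ccc(C(=O)CC(C)C)c1C` gives 33.1% in this assay.

Compound 2 shows the highest of the three numbers in this assay; compound 1 sits within the scatter of it, while compound 3 lies far below it. Compound 4 `Cc1c(OCCCCOc2ccc(F)c(C(=O)O)c2)ccc(C(=O)C(C)C)c1O` is built from compound 2 by one change: isopropyl in place of propyl on a carbonyl carbon. Going by the values given here, no measured pair shows this exact change. Among the compounds with values here, the only measured step, a number 6.5 percentage points higher from compound 1 to compound 2 (within the scatter), alters a group one bond further out from the carbonyl and stayed within the scatter, so a small step is expected here too, with no clear direction. Compound 4 is therefore estimated at 82%, with a range from 60% to 100%, which means an expected step of a number 5.5 percentage points lower from compound 2 to compound 4 (within the scatter).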

Compound 4, largest response reached (reported as percent of maximum), in percent of the reference or control that the assay uses: 74.1%
Compound 4: middle estimate off by 7.9 percentage points, on the high side; measured number inside the range.
By their numbers in this assay, from the lowest: compound 3; then compounds 4, 1 and 2 (each within the scatter of the next, the first and the last beyond it).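

Replacing propyl with isopropyl on a carbonyl carbon gives a number 13.4 percentage points lower from compound 2 to compound 4 (beyond the scatter) in this assay and is the first step among these groups to pass the scatter, so rearranging the same carbons here can alter the maximal response. Isopropyl in place of cyclopentylmethyl gives a number 6.9 percentage points lower from compound 1 to compound 4 (within the scatter) and so stays inside the scatter. Nothing here explains why these two steps differ. Going by these compounds alone, with only one group branched at the carbon bound to the carbonyl, this may be a single case. A tert-butyl or a longer chain such as pentyl would test whether the pattern holds.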